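Aryl swap on the amine of the shared core

The compounds below may be only part of what the source reports. "The series", "measured", "known", "first", "only" and "open" are said of these compounds alone.

In a functional assay on HL-60 cells (Homo sapiens) for cytotoxicity, read by MTT assay, with a stated time of 48 h (a lower number here means a stronger inhibitor, a higher number a weaker inhibitor), compound 2 `Fc1cccc(-c2nc(Nc3ccccc3F)c3cc(F)ccc3n2)c1` gives > 50000 nM, which is a limit of the assay and not a number. Compound 1 `Fc1ccc(Nc2nc(-c3cccc(F)c3)nc3ccc(F)cc23)cc1` likewise gives > 50000 nM in this assay, again a limit. The step that the two limits leave unreadable from compound 1 to compound 2 is therefore unreadable; the limit of > 50000 nM in this assay, at which 2 of the 2 values shown sit, is all that the two values show. Compound 3 `Fc1cccc(-c2nc(Nc3ccc(Cl)cc3)c3cc(F)ccc3n2)c1` differs from compound 2 by 4-chlorophenyl in place of 2-fluorophenyl on a nitrogen on an aromatic ring. For the measured compounds named here, no measured step bears on this change, so no direction can be read from the series. The step of a number no higher from compound 2 to compound 3 (the limit leaves the size open) is estimated to stay within the scatter. Compound 3 is expected to give about 50000 nM, within 20000 nM to 150000 nM, most likely again as a limit.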

Compound 3, half-maximal inhibitory concentration: 45700 nM
Compound 3: middle estimate off by 1.1-fold (0.04 log units), on the high side, and the stated range covers the measured number.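

Of the three compounds, only compound 3 gives a number rather than a limit in this assay, with 4-chlorophenyl on a nitrogen on an aromatic ring. The change reads as an at least 1.0-fold lower number from compound 2 to compound 3 (0.03 log units; that floor lies within the scatter), and chloro in place of fluoro on an aromatic carbon reads as an at least 1.0-fold lower number from compound 1 to compound 3 (0.03 log units; that floor lies within the scatter), so neither step is shown to pass the scatter. Most of the series still sits at a limit: the limit of > 50000 nM in this assay, at which 2 of the 3 values shown sit.

As far as these compounds go, whether an amine or a carboxylic acid on that phenyl ring would give a step beyond the scatter remains open.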